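Moving the Thiophene Attachment and Adding Chlorine

This account rests on a few compounds, and the source may have more. Where it says the series, first, only, none or still open, it means among the compounds named here.

Measured in a functional assay on the whole organism (strain Wistar) for inhibition, with Rattus norvegicus as the target, read by paw edema, with stated times of 30 min and 1 h, at a dose of 20 mg/kg; a higher number here means more inhibition at the dose given (going by the name of the read-out), a lower number less inhibition:
compound 1 `CCOC(=O)C1=C(C)NC(C)=C(C(=O)OCC)C1c1ccc(OCC(=O)Nc2c(C)cccc2C)cc1` gives 26.3%
compound 2 `CCOC(=O)C1=C(C)NC(C)=C(C(=O)OCC)C1c1ccc(OCC(=O)NNC(=O)c2ccccc2)cc1` gives 29.5%
compound 3 `CCOC(=O)C1=C(C)NC(C)=C(C(=O)OCC)C1c1ccc(OCC(=O)NNC(=O)c2cccs2)cc1` gives 55.1%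

Compound 3 stands highest of the three. Its lead over compound 1 is a number 28.8 percentage points higher from compound 1 to compound 3 (beyond the scatter), and over compound 2 it is a number 25.6 percentage points higher from compound 2 to compound 3 (beyond the scatter); both steps are beyond the scatter, so compound 3 has the highest number of the measured set. Between compound 1 and compound 2 the step is a number 3.2 percentage points higher from compound 1 to compound 2 (within the scatter), which says nothing about order.

Compound 4 `CCOC(=O)C1=C(C)NC(C)=C(C(=O)OCC)C1c1ccc(OCC(=O)NNC(=O)c2ccsc2Cl)cc1` differs from compound 3 in one place: 2-chlorothiophen-3-yl in place of thiophen-2-yl on a carbonyl carbon. Among the compounds with values here, only one measured step touches the same carbonyl carbon, the change from phenyl to thiophen-2-yl in a number 25.6 percentage points higher from compound 2 to compound 3 (beyond the scatter), and it was modest. Within the data shown here, that step shows a thiophene ring can matter here, but no measured pair shows what shifting the ring attachment or adding chlorine does. With that gap, the safest expectation is a step that stays within the scatter or drops slightly, estimated as a number 9.1 percentage points lower from compound 3 to compound 4 (within the scatter). Compound 4 is therefore expected to give about 46% in this assay, with a likely range from 28% to 62%.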

Compound 4, a percentage reported as inhibition, in the whole organism at one dose (the size of the read-out at that dose, not a potency): 42.3%
Beside the measured number, compound 4's estimate is 3.7 percentage points above it; measured number inside the range.
By their numbers in this assay, from the lowest: compounds 1 and 2 (each within the scatter of the next); then compound 4; then compound 3.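

In this assay, the carbonyl carbon turns out to tell one thiophene group from another, not just a thiophene from phenyl: putting 2-chlorothiophen-3-yl in place of thiophen-2-yl gives a number 12.8 percentage points lower from compound 3 to compound 4 (beyond the scatter) and leaves compound 3 as the highest of the four. The loss is only partial, since the change from phenyl gives a number 12.8 percentage points higher from compound 2 to compound 4 (beyond the scatter) and the larger replacement on the amide-type nitrogen, where the 2,6-dimethylphenyl group leaves, gives a number 16 percentage points higher from compound 1 to compound 4 (beyond the scatter) so a thiophene group carrying chlorine still stands clear of both compounds without a thiophene. Nothing measured here explains why the number falls from the thiophen-2-yl group to the chlorinated group.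

From the compounds shown here alone, this single step moves the ring attachment and adds chlorine together, so the share of each stays open, and plain thiophen-3-yl or 5-chlorothiophen-2-yl would separate the two. Also open, going by these compounds, is how other groups on the same thiophene ring would read in this assay for example methyl, bromine or an amine in place of the chlorine.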